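Swapping the Substituent on the Ring Nitrogen: Expected Flat Outcome

The source may hold more compounds than are shown below. What is called first, only, known or untested is meant among the compounds shown, and "the series" means these compounds.

Three compounds have been measured in an assay on CHO cells for displacement of a labelled ligand from adenosine receptor A1 (Homo sapiens), read by scintillation counting, with a stated time of 120 min, tested at 10 uM; a lower number here means less inhibition, a higher number more inhibition at the concentration tested (going by the name of the read-out):
compound 1, `Nc1scc(CN2CCN(c3ccc([N+](=O)[O-])cc3)CC2)c1C(=O)c1ccc(Cl)cc1`, gives 1%
compound 2, `Nc1scc(CN2CCN(C3CCCCCC3)CC2)c1C(=O)c1ccc(Cl)cc1`, gives 0%
compound 3, `Nc1scc(CN2CCN(c3cccc4ccccc34)CC2)c1C(=O)c1ccc(Cl)cc1`, gives 1%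

Compound 3 stands level with compound 1 at the digits given, and the two together are the highest of the three numbers, though all three lie within the usual scatter of one another. The steps among them are small: a number 1 percentage points lower from compound 1 to compound 2 (within the scatter), no change at the digits printed from compound 1 to compound 3 (within the scatter) and a number 1 percentage points higher from compound 2 to compound 3 (within the scatter), each within the scatter.

Compound 4, `Nc1scc(CN2CCN(c3ccc(F)c(F)c3)CC2)c1C(=O)c1ccc(Cl)cc1`, has not yet been measured. It differs from compound 3 in one place: 3,4-difluorophenyl in place of naphthalen-1-yl on an amine nitrogen in a ring. Among the measured compounds shown here, the steps that bear on this change are those that exchange the group on the same ring nitrogen, no change at the digits printed from compound 1 to compound 3 (within the scatter) and a number 1 percentage points higher from compound 2 to compound 3 (within the scatter), and neither moved the number beyond the scatter. Three different groups at this position, 4-nitrophenyl, cycloheptyl and naphthalen-1-yl, all gave essentially nothing in this assay, so no step beyond the scatter is expected for compound 4. The expected step for compound 4 is no change at the digits printed from compound 3 to compound 4 (within the scatter). Compound 4 is therefore estimated at 1%, between -6% and 9%.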

Compound 4, a percentage reported as inhibition, at one concentration (the size of the read-out at that concentration, not a potency): 0%
Beside the measured number, compound 4's estimate is 1 percentage points above it, within the range that was stated.
By their numbers in this assay, from the lowest: compounds 2, 4, 1 and 3 (each within the scatter of the next).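

In this assay, among the compounds shown here, 3,4-difluorophenyl brings the first fluorine-bearing group to the amine nitrogen in the ring, and the exchange gives a number 1 percentage points lower from compound 3 to compound 4 (within the scatter), along with no change at the digits printed from compound 2 to compound 4 (within the scatter) and a number 1 percentage points lower from compound 1 to compound 4 (within the scatter). Four groups on this nitrogen now give readings that all lie within the scatter of one another, and the step from naphthalen-1-yl, with 10 heavy atoms and two six-membered aromatic rings, to 3,4-difluorophenyl, with 8 heavy atoms and one such ring, adds a change of ring count and size that still leaves the number within the scatter. Nothing among the data shown explains why the readings at this position stay so close together.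

Whether any group on this ring nitrogen can give a reading beyond the scatter in this assay remains open, since a benzyl group, a carboxylic acid and a hydroxyethyl chain are not among the compounds shown. Also open, going by these compounds, is whether a change elsewhere on the shared core, such as an amide or a methyl ester in place of the chlorine, would alter the reading, since all four compounds keep that core unchanged.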